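The compounds below may be only part of what the source reports. "The series", "measured", "known", "first", "only" and "open" are said of these compounds alone.

Working notes on the series in a functional assay on A2780cisR cells (Homo sapiens) for antiproliferative activity; on this read-out higher numbers stand for weaker inhibition and lower numbers for stronger inhibition.

Two compounds are measured. Compound 1, `CC(C)=CCC/C(C)=C/Cc1c(O)cc2c(c1O)C(=O)[C@H](O)[C@@H](c1ccc(O)cc1)O2`, gives 23500 nM. Compound 2, `CC(C)=CCC/C(C)=C/Cc1c(O)cc2c(c1O)C(=O)[C@H](O)[C@@H](c1ccc(O)c(O)c1)O2`, gives 11500 nM and stands lowest of the two numbers, with compound 1 as its nearest neighbour. For the measured compounds named here, the only measured step, a 2.0-fold lower number from compound 1 to compound 2 (0.31 log units; beyond the scatter), is hydroxy in place of hydrogen on an aromatic carbon, a modest move beyond the scatter.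

Compound 3, `CC(C)=CCC/C(C)=C/Cc1c(O)cc2c(c1O)C(=O)C[C@@H](c1ccc(O)c(O)c1)O2`, differs from compound 2 by hydrogen in place of hydroxy on a saturated ring carbon. The change sits on a saturated ring carbon of the six-membered non-aromatic ring that forms part of the fused system, not on an aromatic carbon, so the step from compound 1 to compound 2 does not address the same place. Going by the values given here, it is the only step available and it bears on the present change only loosely: it shows that adding a hydroxy elsewhere in the core moved the number modestly. Among the compounds with values here, with no direct precedent, the expectation is a step of no more than the usual scatter, in no set direction.

The expected step is a 1.0-fold higher number from compound 2 to compound 3 (0.02 log units; within the scatter), within the scatter. Compound 3 is therefore estimated at 12000 nM, in the range 5000 nM to 30000 nM.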

Compound 3, half-maximal inhibitory concentration: 10500 nM
Compound 3: middle estimate off by 1.1-fold (0.06 log units), on the high side, and the stated range covers the measured number.
By their numbers in this assay, from the lowest: compounds 3 and 2 (each within the scatter of the next); then compound 1.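

Hydrogen in place of hydroxy on a saturated ring carbon, next to the ring atom that bears a 3,4-dihydroxyphenyl group, is the first change read at this position, and in this assay it gives a 1.1-fold lower number from compound 2 to compound 3 (0.04 log units; within the scatter) and so leaves compounds 2 and 3 indistinguishable. With the 3,4-dihydroxyphenyl group in place, the hydroxy on this saturated ring carbon is therefore not required to keep the number where compound 2 has it, a point that the aromatic step between compounds 1 and 2 could not address. Nothing measured alongside these numbers gives a reason for this outcome.

For the compounds shown here, it remains open whether the same indifference to this hydroxy holds with the aryl group of compound 1, since only the pair carrying the 3,4-dihydroxyphenyl group has been compared at this position. Also open is whether this saturated ring carbon tolerates anything larger or differently charged than hydroxy or hydrogen, such as a methoxy group, an amine or a carboxylic acid, which the compounds shown do not reach.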